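The source may report more compounds than this note shows. Statements on the series, on what has been measured and on what is new or still open speak of the compounds shown alone.

Measured so far in an ADME assay on microsomes from liver (Homo sapiens) for metabolic stability, with a stated time of 10 min; a higher number here means that more of the compound is left, a lower number that less of the compound is left:
compound 1 `O=C(NS(=O)(=O)c1ccc(F)cc1)c1ccc(Nc2nc(NC3(c4ccc(Cl)cc4)CC3)nc(OCC(F)(F)F)n2)cc1` gives 100%
compound 2 `CC(C)(C)OC(=O)NCCS(=O)(=O)NC(=O)c1ccc(Nc2nc(NC3(c4ccc(Cl)cc4)CC3)nc(OCC(F)(F)F)n2)cc1` gives 92%
compound 3 `CC(C)C(=O)NCCS(=O)(=O)NC(=O)c1ccc(Nc2nc(NC3(c4ccc(Cl)cc4)CC3)nc(OCC(F)(F)F)n2)cc1` gives 86%

Among these three numbers compound 1 stands highest. Its nearest neighbour is compound 2, a change of a number 8 percentage points lower from compound 1 to compound 2 (within the scatter), which says nothing about order between the two. The furthest is compound 3, with a number 14 percentage points lower from compound 1 to compound 3 (beyond the scatter), a modest loss. Between the two chains themselves, a number 6 percentage points lower from compound 2 to compound 3 (within the scatter) is again no more than the noise of repeated measurement.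

Compound 4 `O=C(NS(=O)(=O)c1ccccc1)c1ccc(Nc2nc(NC3(c4ccc(Cl)cc4)CC3)nc(OCC(F)(F)F)n2)cc1` is compound 1 with one small change: hydrogen in place of fluoro on an aromatic carbon. Among the measured compounds shown here, none of the measured steps touches this spot directly. The two steps that start from compound 1 each exchange the whole 4-fluorophenyl on the sulfonyl sulfur for a chain, and even the larger of those, a number 14 percentage points lower from compound 1 to compound 3 (beyond the scatter), was only modest. Taking away a single fluoro while the phenyl stays is a far smaller alteration than either of those, so no step beyond the scatter is expected in this assay; the estimate is a number 7 percentage points lower from compound 1 to compound 4 (within the scatter). Compound 4 is therefore expected to give about 93%, with a likely range from 80% to 100%.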

Compound 4, percent of the compound remaining: 100%
Compound 4: the middle estimate sits 7 percentage points below what was measured, and the stated range covers the measured number.
By their numbers in this assay, from the lowest: compounds 3, 2, 1 and 4 (each within the scatter of the next, the first and the last beyond it).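

Taking the fluoro off the phenyl ring leaves the number in this assay unmoved, with no change at the digits printed from compound 1 to compound 4 (within the scatter), so at this spot on the ring, para to a large group, the fluoro is not needed to keep the read-out where it stands. The plain phenyl also compares with the two chains much as the 4-fluorophenyl does: there is a number 14 percentage points higher from compound 3 to compound 4 (beyond the scatter), a modest gap to the isopropylcarbonyl chain, while a number 8 percentage points higher from compound 2 to compound 4 (within the scatter) stays inside the noise for the tert-butoxycarbonyl chain. Nothing available explains why this position tolerates the change or why the chains differ as they do.

With both compound 1 and compound 4 at the very top of the read-out, these results show only that hydrogen and fluoro cannot be told apart here, not how much room the position has for other groups. Going by these compounds, whether a larger or differently built group at the same spot, such as a methoxy, an amine or a carboxylic acid, would keep this number remains open.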